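The source may hold more compounds than are shown below. What is called first, only, known or untested is meant among the compounds shown, and "the series" means these compounds.

Compound 1 `CC1(C)COC2(C[C@H]3C[C@@H](CO)C[C@H]3C2)OC1`, compound 2 `CC(C)(C)[Si](O[C@H]1C[C@H]2CC(=O)C[C@H]2C1)(c1ccccc1)c1ccccc1` and compound 3 `BrC1C[C@H]2[C@H](CC(Br)C23OCCO3)C12CCCC2` have been tested in a functional assay on KB 3-1 cells (Homo sapiens) for antiproliferative activity, read by MTT assay; a lower number here means a stronger inhibitor, a higher number a weaker inhibitor. Compound 1 gives > 40 ug/mL, which is a limit and not a number. Compound 2 gives > 40 ug/mL, also a limit. Compound 3 gives > 40 ug/mL, again a limit. Compound 2 therefore offers no exact starting number, and it stands with the others: the limit of > 40 ug/mL in this assay, at which 3 of the 3 values shown sit. Compound 4 `CC(C)(C)[Si](OC1CCCCCC1)(c1ccccc1)c1ccccc1` changes compound 2 on an oxygen whose other neighbours are silicon, with cycloheptyl entering: a group of 7 heavy atoms (7 carbon; one seven-membered non-aromatic ring of carbon only) in place of a group of 9 heavy atoms (8 carbon, 1 oxygen; 2 five-membered non-aromatic rings of carbon only), on an oxygen. For the measured compounds named here, no measured pair shows the effect of such a swap, so no change beyond the usual scatter is expected. The estimated step is a number no higher from compound 2 to compound 4 (the limit leaves the size open). In this assay, compound 4 is expected near 40 ug/mL, within an estimated range of 20 ug/mL to 80 ug/mL.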

Compound 4, half-maximal inhibitory concentration: 6.2 ug/mL
Estimate against measurement, compound 4: 6.5-fold (0.81 log units) above; measured number outside the range, below it.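

In this assay, replacing the two-ring group on the oxygen with cycloheptyl gives an at least 6.4-fold lower number from compound 2 to compound 4 (0.80 log units; beyond the scatter). This shows that the group at this place can change the result, while the rest of the molecule stays the same. The true size of the step remains unknown, since compound 2 offers only a limit: the limit of > 40 ug/mL in this assay, at which 3 of the 4 values shown sit.

The compounds shown do not tell whether the seven-membered ring itself matters, or whether a cyclopentyl ring or an open heptyl chain would serve equally well. Nor do they show how an amine on the ring would fare.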